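Iodo to methyl: an expected antiproliferative step

The compounds below may be only part of what the source reports. "The series", "measured", "known", "first", "only" and "open" are said of these compounds alone.

Measured in a functional assay on HeLa cells (Homo sapiens) for antiproliferative activity, with a stated time of 48 h; a higher number here means a weaker inhibitor, a lower number a stronger inhibitor:
- Compound 1 `C=C(Br)C(=O)Nc1ccc(/C=C/C(=O)c2ccc(Cl)c(Cl)c2)cc1`: 3200 nM
- Compound 2 `C=C(Br)C(=O)Nc1ccc(/C=C/C(=O)c2ccc(Br)cc2)cc1`: 1000 nM
- Compound 3 `C=C(Br)C(=O)Nc1ccc(/C=C/C(=O)c2ccc(I)cc2)cc1`: 7700 nM

Compound 3 stands at the top of these numbers, and so it is the weakest inhibitor of the three in this assay. Its nearest neighbour is compound 1 and its furthest is compound 2.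

Compound 4 `C=C(Br)C(=O)Nc1ccc(/C=C/C(=O)c2ccc(C)cc2)cc1` differs from compound 3 by a single change: methyl in place of iodo on an aromatic carbon. Going by the values given here, no measured compound carries this methyl, so no measured step covers the change directly. Three steps on the same ring bear on it. The largest is a 7.7-fold higher number from compound 2 to compound 3 (0.89 log units; beyond the scatter), for iodo in place of bromo. The other two are a 2.4-fold higher number from compound 1 to compound 3 (0.38 log units; beyond the scatter) and a 3.2-fold lower number from compound 1 to compound 2 (0.51 log units; beyond the scatter). All are modest but beyond the scatter, and both other ring patterns sit lower than the iodo compound. As far as these compounds go, on that limited evidence, a modest move towards a lower number is expected, though the methyl itself remains untested. The expected change is a 3.1-fold lower number from compound 3 to compound 4 (0.49 log units; beyond the scatter). Compound 4 is estimated at 2500 nM, with an expected range from 800 nM to 8000 nM.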

Compound 4, half-maximal inhibitory concentration: 2100 nM
Estimate against measurement, compound 4: 1.2-fold (0.08 log units) above, within the range that was stated.
By their numbers in this assay, from the lowest: compound 2; then compounds 4 and 1 (each within the scatter of the next); then compound 3.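

In this assay, going by these compounds alone, the change at this position, para to a large group, gives a 3.7-fold lower number from compound 3 to compound 4 (0.56 log units; beyond the scatter) and is the first step here that replaces a halogen with a carbon group, showing that the position accepts a methyl without the high number seen with iodo. Methyl does not match bromo, though, with a 2.1-fold higher number from compound 2 to compound 4 (0.32 log units; beyond the scatter) beyond the scatter, so the three single groups at this position separate into bromo at the lowest number, methyl in the middle and iodo at the highest. The comparison with the two-chlorine ring gives a 1.5-fold lower number from compound 1 to compound 4 (0.18 log units; within the scatter) and lies within the scatter, so 4-methylphenyl and 3,4-dichlorophenyl cannot be told apart in this assay, and nothing measured here accounts for the order of the groups.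

The compounds shown leave open where an ethyl, a methoxy, an amine or a carboxylic acid at the same position would fall relative to methyl and bromo. They also leave open whether the order of bromo, methyl and iodo would hold on any core other than the shared one.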